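The source may hold more compounds than are shown below. What is called first, only, known or untested is meant among the compounds shown, and "the series" means these compounds.

Working notes on the series.

Compound 1 `CC(NC(=O)NS(=O)(=O)c1ccc(Cl)cc1)c1cc(Br)ccc1OCc1ccccc1` and compound 2 `Cc1ccc(OCc2ccccc2)c(C(C)NC(=O)NS(=O)(=O)c2ccc(Cl)cc2)c1` share a core; in a functional assay on thoracic aorta (Rattus norvegicus, strain Wistar), with a stated time of 15 min (on this read-out higher numbers stand for an effect only at larger amounts of compound and lower numbers for an effect already at smaller amounts), compound 1 gives 57500 nM, and compound 2 gives 65300 nM. The change between them is bromo in place of methyl on an aromatic carbon, and it made a 1.1-fold lower number from compound 2 to compound 1 (0.06 log units; within the scatter).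

Compound 3 `Cc1ccc(OCc2ccccc2)c(C(C)NC(=O)N(C)S(=O)(=O)c2ccccc2)c1` carries a different core; the difference between the core of compound 3 and the core of compound 2 is not broken down here. In this assay compound 3 gives 68200 nM, which lies within the scatter of both compound 1 and compound 2.

Compound 4 `CC(NC(=O)N(C)S(=O)(=O)c1ccccc1)c1cc(Br)ccc1OCc1ccccc1` is not yet measured. It differs from compound 3 by bromo in place of methyl on an aromatic carbon, the same change as from compound 2 to compound 1, at the same place in the same words; among the compounds here this change occurs twice in all.

Within the data shown here, the step from compound 3 to compound 4 in this assay is expected to be a 1.1-fold lower number from compound 3 to compound 4 (0.04 log units; within the scatter), beside the earlier 1.1-fold lower number from compound 2 to compound 1 (0.06 log units; within the scatter), because the only measured instance of this change is a 1.1-fold lower number from compound 2 to compound 1 (0.06 log units; within the scatter) and it stayed within the scatter. Compound 4 is therefore estimated at 62000 nM, expected between 30000 nM and 130000 nM.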

Compound 4, half-maximal effective concentration: 60300 nM
Beside the measured number, compound 4's estimate is 1.0-fold (0.01 log units) above it; the measured number falls inside the stated range.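

Bromo in place of methyl on the aromatic carbon gives a 1.1-fold lower number from compound 3 to compound 4 (0.05 log units; within the scatter), and in this assay the two instances of this change agree: the same change on two cores in this assay, a 1.1-fold lower number (0.06 log units; within the scatter) from compound 2 to compound 1 and a 1.1-fold lower number (0.05 log units; within the scatter) from compound 3 to compound 4, 1.0-fold (0.00 log units) apart, within the scatter of two such steps. On these two cores, then, the change carries over as a step that cannot be told apart from repeated measurement, and the core makes no visible difference to it. This does not show that bromo and methyl differ in their effect in either direction, since both steps lie within the scatter, and two cores give no basis for a rule across the wider series; agreement between two null steps is also weaker evidence of transfer than agreement between two large steps would be.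

Still open, going by these compounds, is whether another group at this aromatic carbon, such as a nitrile or a carboxylic acid, would give a step beyond the scatter. Also open, on these data alone, is whether an amine or a longer chain in place of the benzyloxy group would change the picture.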